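Adding a Methyl Group: From Compound 3 to Compound 4

The source may report more compounds than this note shows. Statements on the series, on what has been measured and on what is new or still open speak of the compounds shown alone.

Measured so far in a functional assay on the whole organism (blood, strain Wistar albino) for inhibition, with Rattus norvegicus as the target, read by colorimetric assay, with stated times of 15 min and 90 min, at a dose of 20 mg/kg by the oral route; a higher number here means more inhibition at the dose given (going by the name of the read-out), a lower number less inhibition:
compound 1, `CCCCNC(=O)NS(=O)(=O)c1ccc(-n2nc(-c3ccccc3)ccc2=O)cc1`, gives 67.4%
compound 2, `CCCCNC(=O)NS(=O)(=O)c1ccc(-n2nc(-c3ccc(C)cc3)ccc2=O)cc1`, gives 86.6%
compound 3, `O=C(NC1CCCCC1)NS(=O)(=O)c1ccc(-n2nc(-c3ccc(Cl)cc3)ccc2=O)cc1`, gives 59%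

Compound 2 differs from compound 1 by methyl in place of hydrogen on an aromatic carbon. In this assay that change gave a number 19.2 percentage points higher from compound 1 to compound 2 (beyond the scatter). Compound 3 has a different core; the difference between the core of compound 1 and the core of compound 3 is not broken down here. The values of compound 3 and compound 1 lie within the scatter of each other, while compound 2 stands beyond the scatter above compound 3.

Compound 4, `Cc1cc(-c2ccc(=O)n(-c3ccc(S(=O)(=O)NC(=O)NC4CCCCC4)cc3)n2)ccc1Cl`, has not yet been measured. It differs from compound 3 by methyl in place of hydrogen on an aromatic carbon. The place is not the same as in compound 2: there the methyl sits para to a large group, here it sits ortho to a chloro group and meta to a large group, so this is the same kind of change, not the same change. Going by the values given here, a rise of similar size is expected, because a number 19.2 percentage points higher from compound 1 to compound 2 (beyond the scatter) is the only guide, but it is expected to be smaller and less certain, since the surroundings of the new methyl are different. The expected step for compound 4 is a number 11 percentage points higher from compound 3 to compound 4 (beyond the scatter). Compound 4 is thus estimated at 70%, between 55% and 85%.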

Compound 4, a percentage reported as inhibition, in the whole organism at one dose (the size of the read-out at that dose, not a potency): 62.1%
Compound 4: the middle estimate sits 7.9 percentage points above what was measured, within the range that was stated.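

In this assay, putting a methyl in place of a hydrogen on the aromatic carbon gave a number 3.1 percentage points higher from compound 3 to compound 4 (within the scatter), so on this core the effect of the change cannot be told apart from the ordinary spread of repeated measurements. The same kind of change therefore did not carry over at the same size from one core to the other: the same change on two cores in this assay, a number 19.2 percentage points higher (beyond the scatter) from compound 1 to compound 2 and a number 3.1 percentage points higher (within the scatter) from compound 3 to compound 4, 16.1 percentage points apart, beyond the scatter of two such steps. This shows that a step seen on one core is a poor guide to the step on the other, but it does not show why, since the two pairs differ both in their cores and in where the methyl sits, and two pairs cannot separate those differences.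

The compounds shown leave open whether a methyl placed as in compound 4 would give a large or a small step on the core of compound 1. They also leave open whether an ethyl or a methoxy group in that place on compound 3 would give a step beyond the scatter.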